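Swapping ethynyl for isopropylamino: clearance expected in mouse

The source may hold more compounds than are shown below. What is called first, only, known or untested is meant among the compounds shown, and "the series" means these compounds.

Of the compounds shown here, two have been measured in an ADME assay on the whole organism (strain ICR) for pharmacokinetics, with Mus musculus as the target, at a dose of 20 mg/kg by the intravenous route; a higher number here means faster removal of the compound, a lower number slower removal. Compound 1 `FC(F)(F)c1ccc(Oc2ccc(-c3noc(-c4c[nH]cn4)n3)cc2)cc1` gives 9.7 mL/min/kg. Compound 2 `C#Cc1c[nH]nc1-c1nc(-c2ccc(Oc3ccc(C(F)(F)F)cc3)cc2)no1` gives 2.4 mL/min/kg, the lower of the two numbers shown, and the only measured step, a 4.0-fold lower number from compound 1 to compound 2 (0.61 log units; beyond the scatter), separates them. Compound 3 `CC(C)Nc1c[nH]nc1-c1nc(-c2ccc(Oc3ccc(C(F)(F)F)cc3)cc2)no1` has not yet been measured. It differs from compound 2 in one place: isopropylamino in place of ethynyl on an aromatic carbon. For the measured compounds named here, no measured step touches this position: the one known step, a 4.0-fold lower number from compound 1 to compound 2 (0.61 log units; beyond the scatter), exchanges one whole five-membered ring group for another and so does not speak directly to the change from compound 2 to compound 3. Without a precedent for this kind of change, the expectation rests on compound 2 alone, and the expected step of a 1.5-fold higher number from compound 2 to compound 3 (0.16 log units; within the scatter) is small, probably within the scatter, with a wide range around it to reflect how little is known. Compound 3 is therefore estimated at 3.5 mL/min/kg, expected to fall between 1.2 mL/min/kg and 10 mL/min/kg in this assay.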

Compound 3, clearance: 15.2 mL/min/kg
Estimate against measurement, compound 3: 4.3-fold (0.64 log units) below; the whole stated range lies below it.
By their numbers in this assay, from the lowest: compound 2; then compounds 1 and 3 (each within the scatter of the next).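

In this assay, this position on the five-membered aromatic ring is clearly sensitive to what it carries: with the rest of the molecule unchanged, isopropylamino in place of ethynyl gives a 6.3-fold higher number from compound 2 to compound 3 (0.80 log units; beyond the scatter). The low number therefore cannot be credited to the 1H-pyrazol-3-yl ring alone, since a compound with that ring and isopropylamino gives a 1.6-fold higher number from compound 1 to compound 3 (0.20 log units; within the scatter), leaving it indistinguishable from the 1H-imidazol-4-yl compound within the usual scatter of this measurement. Nothing available here gives a reason for the size of the step from ethynyl to isopropylamino.

The compounds shown leave open whether the higher number goes with the nitrogen or with the branched carbon chain of isopropylamino, as the two arrive together in a single change. An isopropyl group joined directly to the ring carbon and a simple unsubstituted amine in the same place would separate these two parts, while a nitrile there would show whether ethynyl's low number extends to another small group with a triple bond.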